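From Amide to Amine in a Sphingosine Kinase Series

The compounds below may be only part of what the source reports. "The series", "measured", "known", "first", "only" and "open" are said of these compounds alone.

Compound 1 `CCCCCCCCc1ccc(NC(=O)C(C)(N)CO)cc1` and compound 2 `CCCCCCCCc1ccc(NC(=O)[C@H](N)[C@@H](C)O)cc1` share one core. In an assay on isolated protein for inhibition of sphingosine kinase 1 (Homo sapiens), read by mobility shift assay (a higher number here means a weaker inhibitor, a lower number a stronger inhibitor), compound 1 gives only a limit of > 10000 nM, a limit of the assay (the limit of > 10000 nM in this assay, at which 1 of the 2 values shown sits). Compound 2 gives 1600 nM, the single actual number shown. The step of an at least 6.2-fold lower number from compound 1 to compound 2 (0.79 log units; beyond the scatter) was at least modest. Compound 3 `CCCCCCCCc1ccc(NC[C@@H](N)CO)cc1` differs from compound 2 by 2-amino-3-hydroxypropyl in place of (1-amino-2-hydroxypropyl)carbonyl on a nitrogen on an aromatic ring. Within the data shown here, the only measured step altered the aminoalcohol while keeping the carbonyl; no measured step removes it, so the expectation for compound 3 is loosely founded, and a step of a 1.9-fold higher number from compound 2 to compound 3 (0.27 log units; within the scatter) is expected. Compound 3 is estimated at 3000 nM, between 800 nM and 15000 nM.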

Compound 3, half-maximal inhibitory concentration: 5000 nM
For compound 3 the middle estimate is 1.7-fold (0.22 log units) below the measured one, and the stated range covers the measured number.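

In this assay, among these compounds, 2-amino-3-hydroxypropyl in place of (1-amino-2-hydroxypropyl)carbonyl on a nitrogen on an aromatic ring gave a 3.1-fold higher number from compound 2 to compound 3 (0.49 log units; beyond the scatter), the first measured step to remove the carbonyl, and compound 3 gives 5000 nM. The same change also takes away one carbon and one stereocentre, so the step cannot be assigned to the carbonyl alone. Compound 1 gives only a limit: the limit of > 10000 nM in this assay, at which 1 of the 3 values shown sits. Measured against that limit, the change reads as an at least 2.0-fold lower number from compound 1 to compound 3 (0.30 log units; that floor lies within the scatter).

Still open, on these data alone, is how the number would move with a carboxylic acid in place of the hydroxyl or a longer chain on the shared core.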